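The compounds below may be only part of what the source reports. "The series", "measured", "known", "first", "only" and "open" are said of these compounds alone.

Compound 1 `CC(=O)c1c(NNc2ccc(C)cc2)cc(C)oc1=O`: 53.4%
Compound 2 `CC(=O)c1c(NNc2ccc(Br)cc2)cc(C)oc1=O`: 47.2%

In a functional assay on the whole organism for inhibition, with Rattus norvegicus as the target, read by paw edema, with a stated time of 2 h, at a dose of 50 mg/kg (a lower number here means less inhibition, a higher number more inhibition at the dose given (going by the name of the read-out)), compound 1 gives 53.4%, and compound 2 gives 47.2%. Of the two numbers, that of compound 2 is the smaller, yet a number 6.2 percentage points lower from compound 1 to compound 2 (within the scatter) lies within the scatter, so the two compounds cannot be separated. Compound 3 `CC(=O)c1c(NNc2ccc([N+](=O)[O-])cc2)cc(C)oc1=O` has not been measured; it differs from compound 2 by nitro in place of bromo on an aromatic carbon. Going by the values given here, no measured step exchanges bromo for nitro, and the only step known, a number 6.2 percentage points lower from compound 1 to compound 2 (within the scatter), stayed within the scatter. No step beyond the scatter is therefore expected, a number 0.8 percentage points higher from compound 2 to compound 3 (within the scatter). Compound 3 is estimated at 48%, between 35% and 62%.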

Compound 3, a percentage reported as inhibition, in the whole organism at one dose (the size of the read-out at that dose, not a potency): 55.1%
Compound 3: the middle estimate sits 7.1 percentage points below what was measured; measured number inside the range.
By their numbers in this assay, from the lowest: compounds 2, 1 and 3 (each within the scatter of the next).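

Nitro in place of bromo gives a number 7.9 percentage points higher from compound 2 to compound 3 (within the scatter) and nitro in place of methyl gives a number 1.7 percentage points higher from compound 1 to compound 3 (within the scatter) in this assay on the aromatic carbon para to a large group. Nitro, with three heavy atoms and two hydrogen-bond acceptors, thus joins methyl and bromo with no step beyond the scatter, and the three groups cannot be separated at this position. Nothing at hand accounts for this result. From the compounds shown here alone, whether an amine, a carboxylic acid or a longer chain at this position would also stay within the scatter remains open. So does the effect of changes elsewhere on the shared core.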